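The source may report more compounds than this note shows. Statements on the series, on what has been measured and on what is new or still open speak of the compounds shown alone.

Measured so far, in a functional assay on the whole organism for inhibition, with Rattus norvegicus as the target, read by cytopathic effect and paw edema, at a dose of 100 mg/kg by the oral route; a lower number here means less inhibition, a higher number more inhibition at the dose given (going by the name of the read-out):
compound 1 `CNC(=O)c1c(O)c2cccnc2n(-c2ccccc2)c1=O` gives 21%;
compound 2 `COc1ccc(NC(=O)c2c(O)c3cccnc3n(-c3ccccc3)c2=O)cc1` gives -1.9%.

Among the measured compounds shown here, compound 2 stands lowest of the two numbers, the only other being compound 1, a step of a number 22.9 percentage points lower from compound 1 to compound 2 (beyond the scatter) when 4-methoxyphenyl replaces methyl on the amide-type nitrogen. Compound 3 `Nc1ccc(NC(=O)c2c(O)c3cccnc3n(-c3ccccc3)c2=O)cc1` differs from compound 2 by amino in place of methoxy on an aromatic carbon. For the measured compounds named here, no measured step touches this change: the one step known, a number 22.9 percentage points lower from compound 1 to compound 2 (beyond the scatter), concerns the amide-type nitrogen substituent, not the group on the aromatic ring, so it gives no direction for compound 3. With nothing to anchor a shift either way, the expectation is a step of a number 5.9 percentage points higher from compound 2 to compound 3 (within the scatter) that stays within the scatter. Compound 3 is therefore estimated at 4% in this assay, with a range from -14% to 24%.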

Compound 3, a percentage reported as inhibition, in the whole organism at one dose (the size of the read-out at that dose, not a potency): 0%
The estimate for compound 3 lay 4 percentage points above the measured number; measured number inside the range.
By their numbers in this assay, from the lowest: compounds 2 and 3 (each within the scatter of the next); then compound 1.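

In this assay, amino in place of methoxy on the aromatic carbon, para to a large group, gives a number 1.9 percentage points higher from compound 2 to compound 3 (within the scatter), so the two compounds cannot be told apart and this exchange at this position has no visible effect at the dose given. With 4-aminophenyl in place of methyl on the amide-type nitrogen, the result is a number 21 percentage points lower from compound 1 to compound 3 (beyond the scatter), so the drop first seen with 4-methoxyphenyl also appears with a second substituted phenyl and does not depend on methoxy alone. Nothing measured here offers an explanation for either result.

The compounds shown leave open whether a carboxylic acid or a dimethylamino group at this same aromatic position would move the number. They also leave open whether a plain phenyl or an ethyl group on the amide-type nitrogen would stand nearer to compound 1 or to compound 3.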